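The source may hold more compounds than are shown below. What is called first, only, known or untested is meant among the compounds shown, and "the series" means these compounds.

Compound 1 `COC[C@H]1O[C@@H](n2c(Cl)nc3cc(Cl)c(Cl)cc32)[C@H](OC(C)=O)[C@@H]1OC(C)=O`: 26000 nM
Compound 2 `CCCCOC[C@H]1O[C@@H](n2c(Cl)nc3cc(Cl)c(Cl)cc32)[C@H](OC(C)=O)[C@@H]1OC(C)=O`: 66000 nM
Compound 3 `CC(=O)OC1C(CF)OC(n2c(Cl)nc3cc(Cl)c(Cl)cc32)C1OC(C)=O`: 32000 nM

All three numbers come from a functional assay on HFF cells (Homo sapiens) for cytotoxicity (a higher number here means a weaker inhibitor, a lower number a stronger inhibitor), and are read there. Compound 3 at 32000 nM lies within the scatter of compound 1 and beyond the scatter of compound 2, which has the higher number.

The next compound is compound 4 `CC(=O)OC1C(CI)OC(n2c(Cl)nc3cc(Cl)c(Cl)cc32)C1OC(C)=O`, which carries iodo in place of fluoro on a saturated chain carbon bound to a saturated ring carbon. Among the compounds with values here, no measured step exchanges one halogen for another. Within the data shown here, the single step available is a 2.5-fold higher number from compound 1 to compound 2 (0.40 log units; beyond the scatter), a modest one for propyl in place of hydrogen, and it bears on this change only as a rough guide to how far a single edit has moved numbers in this small set. The data give no direction, so no step beyond the scatter is expected in this assay.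

The expected change is a 1.1-fold lower number from compound 3 to compound 4 (0.03 log units; within the scatter) on this estimate. For compound 4 the estimated value is 30000 nM, with an expected range from 11000 nM to 80000 nM as a wide allowance.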

Compound 4, half-maximal inhibitory concentration: 32000 nM
For compound 4 the middle estimate is 1.1-fold (0.03 log units) below the measured one; the range from low to high includes it.
By their numbers in this assay, from the lowest: compounds 1, 3 and 4 (each within the scatter of the next); then compound 2.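

In this assay iodo in place of fluoro on a saturated chain carbon bound to a saturated ring carbon gives no change at the digits printed from compound 3 to compound 4 (within the scatter) as the first halogen exchange read in this series. Within the data shown here, at this place, then, fluoromethyl and iodomethyl cannot be told apart in this read-out, whereas the only earlier step, a 2.5-fold higher number from compound 1 to compound 2 (0.40 log units; beyond the scatter) for propyl in place of hydrogen, was an edit at a different group that lay beyond the scatter. Nothing measured here offers an explanation for this result.

From the compounds shown here alone, whether chloromethyl or bromomethyl would read the same as this pair remains open. Also open, going by these compounds, is whether an aminomethyl group, a carboxylic acid or a longer chain at this place would leave the number where compound 3 and compound 4 stand.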